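Hydroxy on the triazole phenyl of an oxime ether

The compounds below may be only part of what the source reports. "The series", "measured", "known", "first", "only" and "open" are said of these compounds alone.

Measured so far:
Compound 1 `CC(C)=CCC/C(C)=C/CC/C(C)=C/CC[C@@H]1[C@@]2(C)CC/C(=N\OCc3cn(-c4ccccc4)nn3)C(C)(C)[C@@H]2CC[C@@]1(C)O`: 6160 nM
Compound 2 `CC(C)=CCC/C(C)=C/CC/C(C)=C/CC[C@@H]1[C@@]2(C)CC/C(=N\OCc3cn(-c4ccc(F)cc4)nn3)C(C)(C)[C@@H]2CC[C@@]1(C)O`: 18000 nM
Compound 3 `CC(C)=CCC/C(C)=C/CC/C(C)=C/CC[C@@H]1[C@@]2(C)CC/C(=N\OCc3cn(-c4cccc(Br)c4)nn3)C(C)(C)[C@@H]2CC[C@@]1(C)O`: 11700 nM

In a functional assay on A549 cells (Homo sapiens) for cytotoxicity, read by MTT assay, with a stated time of 48 h (on this read-out higher numbers stand for weaker inhibition and lower numbers for stronger inhibition), compound 1 gives the lowest of the three numbers. Compound 3 stands nearest, a 1.9-fold higher number from compound 1 to compound 3 (0.28 log units; within the scatter), and compound 2 furthest, a 2.9-fold higher number from compound 1 to compound 2 (0.47 log units; beyond the scatter). The pair of compounds 2 and 3 shows a 1.5-fold lower number from compound 2 to compound 3 (0.19 log units; within the scatter).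

Compound 4 `CC(C)=CCC/C(C)=C/CC/C(C)=C/CC[C@@H]1[C@@]2(C)CC/C(=N\OCc3cn(-c4cccc(O)c4)nn3)C(C)(C)[C@@H]2CC[C@@]1(C)O` differs from compound 1 in one place: hydroxy in place of hydrogen on an aromatic carbon, phenyl to 3-hydroxyphenyl. Going by the values given here, the steps that bear on it are the two substitutions on the same ring, from compound 1 to compound 2 and from compound 1 to compound 3, both giving higher numbers, one beyond the scatter and one within it. A small rise in this assay is therefore expected for compound 4, likely within the scatter. The expected step is a 1.4-fold higher number from compound 1 to compound 4 (0.14 log units; within the scatter). Compound 4 is estimated at 8500 nM, in the range 3500 nM to 20000 nM.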

Compound 4, half-maximal inhibitory concentration: 12800 nM
The estimate for compound 4 lay 1.5-fold (0.18 log units) below the measured number; measured number inside the range.
By their numbers in this assay, from the lowest: compounds 1, 3, 4 and 2 (each within the scatter of the next, the first and the last beyond it).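

In this assay, hydroxy on the aromatic carbon meta to a large group also fails to give a lower number than hydrogen, this time with a step beyond the scatter (a 2.1-fold higher number from compound 1 to compound 4 (0.32 log units; beyond the scatter)). The swap of bromo for hydroxy at this position leaves the number within the scatter (a 1.1-fold higher number from compound 3 to compound 4 (0.04 log units; within the scatter)), as does the change from 4-fluorophenyl to 3-hydroxyphenyl (a 1.4-fold lower number from compound 2 to compound 4 (0.15 log units; within the scatter)). No evidence is available on what lies behind these steps. The compounds shown leave open whether an amine or a carboxylic acid on this ring would give a number below that of compound 1.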